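Chloro to Methoxy: Expected Paw Edema Inhibition for Compound 4

The source may report more compounds than this note shows. Statements on the series, on what has been measured and on what is new or still open speak of the compounds shown alone.

Compound 1 `CC(Br)C(=O)Nc1ccc(C(=O)/C=C/c2ccc(Cl)cc2)cc1` gives 54% in a functional assay on the whole organism (strain albino) for inhibition, with Rattus norvegicus as the target, read by paw edema, with stated times of 30 min and 4 h, at a dose of 100 mg/kg by the oral route; on this read-out lower numbers stand for less inhibition and higher numbers for more inhibition at the one dose given (going by the name of the read-out). Compound 2 `COc1ccc(/C=C/C(=O)c2ccc(NC(=O)C(C)Br)cc2)cc1` differs from it by methoxy in place of chloro on an aromatic carbon, and in this assay compound 2 gives 38%; that change made a number 16 percentage points lower from compound 1 to compound 2 (beyond the scatter). Compound 3 `CC(=O)c1ccc(OCC(=O)Nc2ccc(C(=O)/C=C/c3ccc(Cl)cc3)cc2)cc1` gives 58% in this assay, a value that lies within the usual scatter of compound 1 but beyond it relative to compound 2. The difference between the cores of compound 1 and compound 3 is not broken down here. Compound 4 `COc1ccc(/C=C/C(=O)c2ccc(NC(=O)COc3ccc(C(C)=O)cc3)cc2)cc1` has not yet been measured; it differs from compound 3 by methoxy in place of chloro on an aromatic carbon, the same change as that between compound 1 and compound 2, at the same kind of place. The expected step is a number 16 percentage points lower from compound 3 to compound 4 (beyond the scatter), because the same change gave a number 16 percentage points lower from compound 1 to compound 2 (beyond the scatter). Compound 4 is therefore estimated at 42%, with a likely range from 28% to 56%.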

Compound 4, a percentage reported as inhibition, in the whole organism at one dose (the size of the read-out at that dose, not a potency): 33%
The estimate for compound 4 lay 9 percentage points above the measured number, and the stated range covers the measured number.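

Methoxy in place of chloro gave a number 25 percentage points lower from compound 3 to compound 4 (beyond the scatter) in this assay and so moved the number the same way on this second core. The two steps do not differ in size beyond what repeated measurements allow: the same change on two cores in this assay, a number 16 percentage points lower (beyond the scatter) from compound 1 to compound 2 and a number 25 percentage points lower (beyond the scatter) from compound 3 to compound 4, 9 percentage points apart, within the scatter of two such steps. This shows that the change carried over between these two cores in this assay, but two pairs cannot show that it would hold on any other core, and they do not explain why the number falls.

The compounds shown leave open what other groups at the same place on the aromatic ring, such as fluoro, hydroxyl or an amine, would give. They also leave open whether a carboxylic acid or a longer chain on the amide side would alter the step.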